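The compounds below may be only part of what the source reports. "The series", "measured", "known", "first", "only" and "open" are said of these compounds alone.

Two compounds of a shared core were tested in an assay on isolated protein for antagonist activity at RAC-alpha serine/threonine-protein kinase (Homo sapiens), read by surface plasmon resonance, with a stated time of 30 min, tested at 50 uM; a higher number here means more inhibition at the concentration tested (going by the name of the read-out), a lower number less inhibition. Compound 1 `N=C(N/C(=N/O)c1nonc1N)N1CCCN=C1N` gives 92% in this assay, while compound 2 `N=C(N/C(=N/O)c1nonc1N)c1ccccc1` gives 54%, the lower of the two numbers, a gap that lies beyond the usual scatter. Compound 3 `N=C(N/C(=N/O)c1nonc1N)c1ccccc1Br` differs from compound 2 in one place: bromo in place of hydrogen on an aromatic carbon. No comparable change has been measured here, so there is nothing to set a size against. The step from this change is expected to be small, likely within the scatter, as a number 1 percentage points higher from compound 2 to compound 3 (within the scatter). For compound 3 the expected result is 55%, with a range from 30% to 80%.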

Compound 3, a percentage reported as inhibition, at one concentration (the size of the read-out at that concentration, not a potency): 80%
Beside the measured number, compound 3's estimate is 25 percentage points below it, and the stated range covers the measured number.
By their numbers in this assay, from the lowest: compound 2; then compound 3; then compound 1.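

Going by these compounds alone, this is the first sign that the aromatic ring of compound 2 responds to what it carries at this place, ortho to a large group: bromo in place of hydrogen gives a number 26 percentage points higher from compound 2 to compound 3 (beyond the scatter) in this assay. A single change at a single place marks this position as sensitive but does not establish a trend. Nothing available explains the step. As far as these compounds go, whether chlorine, fluorine, a methyl, an amine or a carboxylic acid at the same place would shift the number in the same way stays open. So does the effect of bromo on another carbon of this ring.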